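Trimming a Hydroxyl from a Kinase Inhibitor's Side Chain

The source may hold more compounds than are shown below. What is called first, only, known or untested is meant among the compounds shown, and "the series" means these compounds.

Within the data shown here, compound 2 `COCC(O)Cc1cc(-c2ccnc3[nH]nc(C(F)(F)F)c23)cc(C2(C#N)CC2)c1` gives 77 nM in an assay on isolated protein for inhibition of protein kinase C epsilon type (Homo sapiens), read by coupled enzyme assay (on this read-out lower numbers stand for stronger inhibition and higher numbers for weaker inhibition), the lowest of the two numbers known; compound 1 `CC(C)C(O)Cc1cc(-c2ccnc3[nH]nc(C(F)(F)F)c23)cc(C2(C#N)CC2)c1` gives 215 nM, and the step of a 2.8-fold lower number from compound 1 to compound 2 (0.45 log units; beyond the scatter) separates them. Compound 3 `COCCc1cc(-c2ccnc3[nH]nc(C(F)(F)F)c23)cc(C2(C#N)CC2)c1` differs from compound 2 by methoxymethyl in place of 1-hydroxy-2-methoxyethyl on a saturated chain carbon bound to an aromatic carbon. Among the measured compounds shown here, no measured step touches this hydroxyl, so the change from compound 1 to compound 2 bears on it only loosely. A small rise in the number, or none beyond the scatter, is expected; the estimate for compound 3 is 150 nM (50 nM to 500 nM), a step of a 1.9-fold higher number from compound 2 to compound 3 (0.29 log units; within the scatter).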

Compound 3, inhibition constant: 145 nM
For compound 3 the middle estimate is 1.0-fold (0.01 log units) above the measured one, within the range that was stated.
By their numbers in this assay, from the lowest: compounds 2, 3 and 1 (each within the scatter of the next, the first and the last beyond it).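

In this assay, replacing the 2-hydroxy-3-methoxypropyl chain with 2-methoxyethyl gives a 1.9-fold higher number from compound 2 to compound 3 (0.27 log units; within the scatter), so the hydroxyl is not needed for a value in this range. The other listed step, a 1.5-fold lower number from compound 1 to compound 3 (0.17 log units; within the scatter), also stays within the scatter, so the hydroxyl-free chain cannot be placed in order against either hydroxyl-bearing chain. No supporting evidence explains these results.

This change removes the hydroxyl and shortens the chain together, so their separate contributions remain unresolved. From the compounds shown here alone, how an amine or a carboxylic acid would read at this place also remains open.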